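Swapping the Benzyl Arm for a Carbamoyl

This account rests on a few compounds, and the source may have more. Where it says the series, first, only, none or still open, it means among the compounds named here.

Of the compounds shown here, two that share one core have so far been measured in a functional assay on HL-60 cells (Homo sapiens) for antiproliferative activity, with a stated time of 24 h; on this read-out lower numbers stand for stronger inhibition and higher numbers for weaker inhibition. Compound 1, with the structure `NC(=O)c1c(NC(=O)c2ccccc2Cl)sc2c1CCN(Cc1ccccc1Cl)C2`, gives 2900 nM in this assay. Compound 2, with the structure `NC(=O)c1c(NC(=O)c2ccccc2Cl)sc2c1CCN(C(=S)Nc1ccccc1-c1ccccc1)C2`, gives 34400 nM in this assay. Of these two numbers, compound 1 holds the lower one, and its gap to compound 2 lies beyond the usual scatter, so compound 1 is the stronger inhibitor of the pair.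

Compound 3, with the structure `NC(=O)c1c(NC(=O)c2ccccc2Cl)sc2c1CCN(C(=O)Nc1c(Cl)cccc1Cl)C2`, has not yet been measured in this assay. It differs from compound 1 in one place: (2,6-dichlorophenyl)carbamoyl in place of 2-chlorobenzyl on an amine nitrogen in a ring. For the measured compounds named here, no measured pair traces this exact change. Going by the values given here, what the numbers do show is that compound 1 carries the 2-chlorobenzyl, while compound 2, the only other compound and one that carries a different group on the same ring nitrogen, gives a clearly higher number. On that slender basis, compound 3 is expected to give a higher number than compound 1, meaning weaker inhibition, with the step of a 3.4-fold higher number from compound 1 to compound 3 (0.54 log units; beyond the scatter) estimated as a loss of moderate size. Compound 3 is therefore estimated at 10000 nM in this assay, within a range from 3000 nM to 40000 nM.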

Compound 3, half-maximal inhibitory concentration: 17700 nM
Compound 3: middle estimate off by 1.8-fold (0.25 log units), on the low side, within the range that was stated.
By their numbers in this assay, from the lowest: compound 1; then compounds 3 and 2 (each within the scatter of the next).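

For the compounds shown here, putting (2,6-dichlorophenyl)carbamoyl in place of 2-chlorobenzyl on the amine nitrogen in the ring gives a 6.1-fold higher number from compound 1 to compound 3 (0.79 log units; beyond the scatter) in this assay and so marks a modest loss of inhibition, the first change at this position to be traced as a single step. With three different groups now measured on this nitrogen, the 2-chlorobenzyl of compound 1 holds the lowest number, while compound 3 and compound 2 lie within the usual scatter of each other, so these two quite different replacements cannot be ranked. No measurement shown here accounts for the loss.

This single step changes several things at once, including the link to the nitrogen, the carbonyl, the amide hydrogen and the number of chlorines on the aromatic ring, so the compounds shown leave open which of these matters. As far as these compounds go, a (2,6-dichlorobenzyl) group, an unsubstituted benzyl group or a simple acetyl group on the same nitrogen would each bear on that question, and the effect of any of them remains unknown here.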